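A few compounds are considered here, and "the series" means these few. Any claim that something is new, unique, unknown or untested is made for them only; others in the source may bear on it.

Of the compounds shown here, three sharing one core have been measured in a functional assay on ACHN cells (Homo sapiens) for antiproliferative activity, read by MTT assay, with a stated time of 96 h; on this read-out lower numbers stand for stronger inhibition and higher numbers for weaker inhibition. Compound 1 `O=C1C2=C(C(=O)c3ncccc31)C1(CS2)NC(=O)N(c2ccc([N+](=O)[O-])cc2)C1=O` gives 100 nM, compound 2 `CCCCCc1ccc(N2C(=O)NC3(CSC4=C3C(=O)c3ncccc3C4=O)C2=O)cc1` gives 250 nM, and compound 3 `CCCCc1ccc(N2C(=O)NC3(CSC4=C3C(=O)c3ncccc3C4=O)C2=O)cc1` gives 50 nM. Compound 3 therefore has the lowest number of the three, though its gap to compound 1 lies within the scatter, so no ranking between those two can be claimed; only compound 2 stands clearly apart, as the step of a 5.0-fold lower number from compound 2 to compound 3 (0.70 log units; beyond the scatter) shows. The other steps, a 2.5-fold higher number from compound 1 to compound 2 (0.40 log units; beyond the scatter) and a 2.0-fold lower number from compound 1 to compound 3 (0.30 log units; within the scatter), concern the exchange of the nitro group for a chain.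

Compound 4 `CC(C)(C)c1ccc(N2C(=O)NC3(CSC4=C3C(=O)c3ncccc3C4=O)C2=O)cc1` differs from compound 3 by tert-butyl in place of butyl on an aromatic carbon. Going by the values given here, no measured step alters the shape of the chain while keeping its size; the nearest guide, a 5.0-fold lower number from compound 2 to compound 3 (0.70 log units; beyond the scatter), concerns one chain carbon more or less, and shows that the chain on this carbon matters to the read-out. Without a direct precedent, compound 4 is expected to stay close to compound 3, with a step of a 1.6-fold higher number from compound 3 to compound 4 (0.20 log units; within the scatter) that may not exceed the scatter. Compound 4 is estimated at 80 nM, within 30 nM to 250 nM.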

Compound 4, half-maximal inhibitory concentration: 150 nM
Compound 4: the middle estimate sits 1.9-fold (0.27 log units) below what was measured, within the range that was stated.
By their numbers in this assay, from the lowest: compounds 3, 1, 4 and 2 (each within the scatter of the next, the first and the last beyond it).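

In this assay, the same four carbons arranged as tert-butyl instead of butyl give a 3.0-fold higher number from compound 3 to compound 4 (0.48 log units; beyond the scatter), so on this aromatic carbon the arrangement of the chain counts, not just its number of carbons. Against the other two groups, compound 4 cannot be ranked, given a 1.7-fold lower number from compound 2 to compound 4 (0.22 log units; within the scatter) and a 1.5-fold higher number from compound 1 to compound 4 (0.18 log units; within the scatter). Nothing available here accounts for the effect of the branching.

Still open, from the compounds shown here alone, is how a shorter chain such as propyl, a singly branched chain such as isobutyl, or a ring such as cyclobutyl would compare with butyl and tert-butyl on this carbon. An amine or a carboxylic acid in the same place would show how far the read-out tolerates groups unlike these carbon chains.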